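The source may report more compounds than this note shows. Statements on the series, on what has been measured and on what is new or still open speak of the compounds shown alone.

Of the compounds shown here, three sharing one core have been tested in a toxicity assay on GES1 cells (Homo sapiens) for inhibition, read by MTT assay, with a stated time of 72 h; a lower number here means a stronger inhibitor, a higher number a weaker inhibitor. Compound 1 `Cc1cc(N2CC[C@@H](C)[C@@H](N(C)c3ncnc4[nH]ccc34)C2)n2nc(SCc3ccc(C(F)(F)F)cc3)nc2n1` gives 17300 nM, compound 2 `Cc1cc(N2CC[C@@H](C)[C@@H](N(C)c3ncnc4[nH]ccc34)C2)n2nc(SCCc3ccccc3)nc2n1` gives 66200 nM, and compound 3 `Cc1cc(N2CC[C@@H](C)[C@@H](N(C)c3ncnc4[nH]ccc34)C2)n2nc(SCc3ccc([N+](=O)[O-])cc3)nc2n1` gives 36600 nM. Compound 3 thus stands second highest of the three numbers: its value and that of compound 2 lie within the scatter of each other, while compound 1 sits a 2.1-fold higher number from compound 1 to compound 3 (0.33 log units; beyond the scatter) away.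

Compound 4 `Cc1cc(N2CC[C@@H](C)[C@@H](N(C)c3ncnc4[nH]ccc34)C2)n2nc(SCc3ccc(F)c(Cl)c3)nc2n1` differs from compound 3 in one place: 3-chloro-4-fluorophenyl in place of 4-nitrophenyl on a saturated chain carbon bound to a sulfur. The measured steps that bear on this are a 3.8-fold higher number from compound 1 to compound 2 (0.58 log units; beyond the scatter) and a 2.1-fold higher number from compound 1 to compound 3 (0.33 log units; beyond the scatter), both of which show that a ring carrying a trifluoromethyl group gave a lower number than either a plain benzyl or a nitro-bearing ring, and a 1.8-fold lower number from compound 2 to compound 3 (0.26 log units; within the scatter), which changed little. A halogen-bearing ring in compound 4 is therefore expected to move the number modestly toward that of compound 1, so for compound 4 a step of a 1.7-fold lower number from compound 3 to compound 4 (0.22 log units; within the scatter) is expected in this assay, downward but not by much. Compound 4 is estimated at 22000 nM, with a range from 9000 nM to 50000 nM.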

Compound 4, half-maximal inhibitory concentration: > 100000 nM
Compound 4 was reported as a limit; the forecaster's own chance of this, stated with the estimate: 5%; middle value at least 4.5-fold (0.65 log units) from the limit.
By their numbers in this assay, from the lowest: compound 1; then compounds 3 and 2 (each within the scatter of the next). At a limit, above all of these: compound 4.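

In this assay compound 4 is reported only as a limit, > 100000 nM, so every step to it is a floor and not a measured size, and the result rests on that limit: the limit of > 100000 nM in this assay, at which 1 of the 4 values shown sits. Among these compounds, it shows that a change of the ring on the saturated chain carbon bound to a sulfur can move the number further than the steps among the earlier compounds, and that a ring carrying halogen need not sit with the trifluoromethyl compound: an at least 2.7-fold higher number from compound 3 to compound 4 (0.43 log units; beyond the scatter), and an at least 5.7-fold higher number from compound 1 to compound 4 (0.76 log units; beyond the scatter). The comparison with the remaining compound is less firm, at an at least 1.5-fold higher number from compound 2 to compound 4 (0.17 log units; that floor lies within the scatter), so no order beyond the scatter can be claimed for that pair.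

On these data alone, the true value of compound 4 remains unknown, and so does whether its chlorine or its fluorine matters more. As far as these compounds go, how an amine or a carboxylic acid on this ring would read also stays open.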